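The compounds below may be only part of what the source reports. "The series", "measured", "known", "first", "only" and "open" are said of these compounds alone.

Compound 1 `COc1ccc(COCNc2n[n+]([O-])c3ccccc3[n+]2[O-])cc1` gives 14500 nM
Compound 2 `[O-][n+]1nc(NCOC2CCCCC2)[n+]([O-])c2ccccc21` gives 3250 nM
Compound 3 `CCCOCNc1n[n+]([O-])c2ccccc2[n+]1[O-]` gives 14200 nM

All three were tested in a functional assay on PC-3 cells (Homo sapiens) for cytotoxicity, read by MTT assay, with a stated time of 72 h; on this read-out lower numbers stand for stronger inhibition and higher numbers for weaker inhibition. On these numbers compound 3 has the second highest value; compound 1 lies within the scatter of it, while compound 2 sits clearly lower, as the step of a 4.4-fold higher number from compound 2 to compound 3 (0.64 log units; beyond the scatter) shows.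

Compound 4 `CCOCNc1n[n+]([O-])c2ccccc2[n+]1[O-]` differs from compound 3 by hydrogen in place of methyl on a saturated chain carbon, two bonds along the chain from an oxygen on a saturated carbon. Within the data shown here, two measured steps bear on this. The step of a 1.0-fold lower number from compound 1 to compound 3 (0.01 log units; within the scatter) replaced a large group on the chain carbon bound to the oxygen and changed nothing beyond the scatter. The step of a 4.4-fold higher number from compound 2 to compound 3 (0.64 log units; beyond the scatter) swapped the cyclohexyl for a propyl and raised the number modestly, so trimming the chain on the oxygen side has mattered once, in the direction of weaker inhibition. Removing one more carbon is a smaller change than either of those, so for compound 4 a step of a 1.3-fold higher number from compound 3 to compound 4 (0.10 log units; within the scatter) in this assay is expected, within or barely beyond the scatter, toward a higher number. Compound 4 is therefore estimated at 18000 nM, likely between 7000 nM and 45000 nM.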

Compound 4, half-maximal inhibitory concentration: 15900 nM
Beside the measured number, compound 4's estimate is 1.1-fold (0.05 log units) above it, and the stated range covers the measured number.
By their numbers in this assay, from the lowest: compound 2; then compounds 3, 1 and 4 (each within the scatter of the next).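

In this assay, the step of a 1.1-fold higher number from compound 3 to compound 4 (0.05 log units; within the scatter) stays within the scatter, so these two compounds do not tell propoxy and ethoxy apart at this position. The step of a 1.1-fold higher number from compound 1 to compound 4 (0.04 log units; within the scatter) is also within the scatter, although a 4-methoxyphenyl gives way to a methyl on the saturated chain carbon bound to the oxygen, while the step of a 4.9-fold higher number from compound 2 to compound 4 (0.69 log units; beyond the scatter) lies beyond the scatter, leaving compound 2, with its cyclohexyl on the oxygen, as the only one set apart from the other three. Nothing available here explains these results.

A longer chain, such as butyl or hexyl, could show whether this flat stretch continues. An amine at the end of the ethyl chain, or a cyclopentyl in place of the cyclohexyl, would test how much the value of compound 2 depends on the group on the oxygen.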